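From compound 1 to compound 4: one added fluoro

The source may hold more compounds than are shown below. What is called first, only, known or untested is meant among the compounds shown, and "the series" means these compounds.

Compound 1 `O=C1C=C(N2CCN(c3cccc(Cl)c3)CC2)C(=O)c2ccccc21`: 8300 nM
Compound 2 `COc1cc(OC)cc(N2CCN(C3=CC(=O)c4ccccc4C3=O)CC2)c1`: 14900 nM
Compound 3 `COc1ccc(N2CCN(C3=CC(=O)c4ccccc4C3=O)CC2)cc1OC`: 17800 nM

In a functional assay on DU-145 cells (Homo sapiens) for inhibition, read by MTT assay, with a stated time of 72 h (a lower number here means a stronger inhibitor, a higher number a weaker inhibitor), compound 1 has the lowest number of the three, yet it cannot be separated from compound 2 within the usual scatter. Only its gap to compound 3 lies beyond that scatter.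

Compound 4 `O=C1C=C(N2CCN(c3ccc(F)c(Cl)c3)CC2)C(=O)c2ccccc21` keeps the core of compound 1 and turns 3-chlorophenyl into 3-chloro-4-fluorophenyl: fluoro in place of hydrogen on an aromatic carbon. This places fluoro in place of hydrogen on an aromatic carbon, ortho to a chloro group and para to a large group. Among the measured compounds shown here, no measured pair shows this change, so no step beyond the scatter is expected in this assay. The estimated step is a 1.3-fold lower number from compound 1 to compound 4 (0.11 log units; within the scatter), with a slightly lower number only tentatively expected. The expected value for compound 4 is 6500 nM, within an estimated range of 2800 nM to 15000 nM.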

Compound 4, half-maximal inhibitory concentration: 32200 nM
The estimate for compound 4 lay 5.0-fold (0.69 log units) below the measured number; measured number above the stated range.
By their numbers in this assay, from the lowest: compounds 1, 2, 3 and 4 (each within the scatter of the next, the first and the last beyond it).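

In this assay the added fluoro gives a 3.9-fold higher number from compound 1 to compound 4 (0.59 log units; beyond the scatter) and so a weaker inhibitor. Among the compounds shown here, this is the first direct view of this position, para to a large group and ortho to a chloro group, and it shows that one added heavy atom there can matter, which the earlier compounds, differing in more than one place, could not show. Nothing measured here explains the step.

This single pair leaves open whether the loss is specific to fluoro, or whether a methyl or an amine at this position would behave alike. It also leaves open whether fluoro has the same effect without the neighbouring chloro group.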